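The source may hold more compounds than are shown below. What is called first, only, known or untested is meant among the compounds shown, and "the series" means these compounds.

Compound 3 `COc1nc(C)c(Nc2nc(Cl)cn([C@H](COc3cc(Br)ccn3)C3CC3)c2=O)cc1C` gives 1.5 nM in an assay on frontal cortex for displacement of a labelled ligand from corticotropin-releasing factor receptor 1 (Rattus norvegicus), with a stated time of 2 h (on this read-out higher numbers stand for weaker inhibition and lower numbers for stronger inhibition), the second highest of three numbers, all of which lie within the usual scatter of one another. Compound 1 `COc1nc(C)c(Nc2nc(Cl)cn([C@H](COC(=O)Nc3cc(Cl)cc(Cl)c3)C3CC3)c2=O)cc1C` gives 1.7 nM and compound 2 `COc1nc(C)c(Nc2nc(Cl)cn([C@H](COc3ccccn3)C3CC3)c2=O)cc1C` gives 1.2 nM. Compound 4 `COc1nc(C)c(Nc2nc(Cl)cn([C@H](COc3cccnc3)C3CC3)c2=O)cc1C` differs from compound 3 by pyridin-3-yl in place of 4-bromopyridin-2-yl on an oxygen on a saturated carbon. Among the compounds with values here, the steps that bear on this change all concern the same oxygen on a saturated carbon: a 1.4-fold lower number from compound 1 to compound 2 (0.15 log units; within the scatter), a 1.1-fold lower number from compound 1 to compound 3 (0.05 log units; within the scatter) and a 1.3-fold higher number from compound 2 to compound 3 (0.10 log units; within the scatter), each within the scatter. A further pyridyl group at the same place is therefore expected to give no step beyond the scatter, so for compound 4 a step of a 1.1-fold higher number from compound 3 to compound 4 (0.03 log units; within the scatter) is expected. Compound 4 is estimated at 1.6 nM, within a range of 0.7 nM to 3.6 nM.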

Compound 4, half-maximal inhibitory concentration: 6.7 nM
Compound 4: middle estimate off by 4.2-fold (0.62 log units), on the low side; measured number above the stated range.
By their numbers in this assay, from the lowest: compounds 2, 3 and 1 (each within the scatter of the next); then compound 4.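

In this assay, within the data shown here, the oxygen on a saturated carbon proves less forgiving than the earlier compounds suggested, since pyridin-3-yl gives steps beyond the scatter: a 5.6-fold higher number from compound 2 to compound 4 (0.75 log units; beyond the scatter) and a 4.5-fold higher number from compound 3 to compound 4 (0.65 log units; beyond the scatter) and a 3.9-fold higher number from compound 1 to compound 4 (0.60 log units; beyond the scatter) in turn. The step from the pyridin-2-yl compound shows that the way the pyridine ring is attached to this oxygen matters, since nothing else changes. Nothing available explains this step. As far as these compounds go, it remains open whether pyridin-4-yl or plain phenyl at this oxygen would follow pyridin-2-yl or pyridin-3-yl. From the compounds shown here alone, whether bromo on the pyridin-3-yl ring would change the number is also open.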